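A few compounds are considered here, and "the series" means these few. Any claim that something is new, unique, unknown or untested is made for them only; others in the source may bear on it.

Measured so far:
compound 1 `COc1cc(NC(=O)Nc2cc(Nc3ccc(OC)c(C)c3)ncn2)cc(OC)c1` — 13.5%
compound 2 `CC(C)(C)c1cccc(Nc2cc(NC(=O)Nc3c(Cl)cccc3Cl)ncn2)c1` — 29.6%

In a functional assay on NCI-H520 cells (Homo sapiens) for inhibition, read by MTT assay, with a stated time of 48 h, tested at 10 uM (on this read-out lower numbers stand for less inhibition and higher numbers for more inhibition at the one concentration tested (going by the name of the read-out)), compound 1 gives 13.5%, the lower of the two numbers; compound 2 gives 29.6%, a number that stands higher by more than the usual scatter. Among the measured compounds shown here, no pair of measured compounds differing in one place exists, so no step size is known for any single change.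

Compound 3 `COc1cc(NC(=O)Nc2cc(Nc3ccc(Br)cc3OC)ncn2)cc(OC)c1` differs from compound 1 by 4-bromo-2-methoxyphenyl in place of 4-methoxy-3-methylphenyl on a nitrogen on an aromatic ring. For the measured compounds named here, with only two low readings to go on, the step from compound 1 to compound 3 is expected to be modest and upward, a number 6.5 percentage points higher from compound 1 to compound 3 (within the scatter). Compound 3 is estimated at 20%, ranging from 5% to 45%.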

Compound 3, a percentage reported as inhibition, at one concentration (the size of the read-out at that concentration, not a potency): 36.1%
Compound 3: the middle estimate sits 16.1 percentage points below what was measured, within the range that was stated.
By their numbers in this assay, from the lowest: compound 1; then compounds 2 and 3 (each within the scatter of the next).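

In this assay, among the compounds shown here, the step of a number 22.6 percentage points higher from compound 1 to compound 3 (beyond the scatter) is the first single change that can be read, and it comes from 4-bromo-2-methoxyphenyl in place of 4-methoxy-3-methylphenyl on a nitrogen on an aromatic ring. This position therefore responds to the choice of aromatic group while the rest of compound 1 stays the same and the heavy-atom count is unchanged. Nothing available explains the step.

The change swaps both substituents at once, so the bromine and the methoxy cannot be separated. From the compounds shown here alone, whether a dimethylamino group on that ring would carry the reading further remains open.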